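Pyrrolopyrimidine series: removing the carbamoyl of compound 3

The source may report more compounds than this note shows. Statements on the series, on what has been measured and on what is new or still open speak of the compounds shown alone.

Measured so far:
compound 1 `C[C@@H]1CCCN1c1c(C#N)c2c(N)nc(Nc3cn(C)nc3C(F)(F)F)nc2n1C` — 358 nM
compound 2 `Cn1c(-c2cccc(F)c2F)c(C#N)c2c(N)ncnc21` — 159 nM
compound 3 `C[C@@H]1CCCN1c1c(C(N)=O)c2c(N)ncnc2n1C` — 2240 nM

In an assay on isolated protein for inhibition of Leucine-rich repeat serine/threonine-protein kinase 2 variant G2019S (Homo sapiens), read by TR-FRET and LanthaScreen, with stated times of 50 min and 30 min, in the presence of a further agent that is not named here (a lower number here means a stronger inhibitor, a higher number a weaker inhibitor), compound 3 gives the highest number of the three, beyond the scatter from compound 1 and further still from compound 2, both of which carry a nitrile where compound 3 carries a carbamoyl. Compound 4 `C[C@@H]1CCCN1c1cc2c(N)ncnc2n1C` is not yet measured; it differs from compound 3 by hydrogen in place of carbamoyl on an aromatic carbon. Going by the values given here, no measured pair shows this change, so the direction rests only on the spread between compound 3 and the nitrile compounds. A small step is expected, within or just beyond the scatter, probably toward a higher number: the estimate for compound 4 is 2800 nM (range 700 nM to 11000 nM), which means an expected step of a 1.3-fold higher number from compound 3 to compound 4 (0.10 log units; within the scatter).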

Compound 4, half-maximal inhibitory concentration: 6390 nM
Compound 4: the middle estimate sits 2.3-fold (0.36 log units) below what was measured; the measured number falls inside the stated range.
By their numbers in this assay, from the lowest: compound 2; then compound 1; then compound 3; then compound 4.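

Hydrogen in place of carbamoyl on this aromatic carbon, next to the ring atom that bears the 2-methylpyrrolidin-1-yl group, gives a 2.9-fold higher number from compound 3 to compound 4 (0.46 log units; beyond the scatter) in this assay as the first matched pair at this position. Going by these compounds alone, the carbamoyl is therefore not dispensable here, although compound 3 has the highest number among the earlier compounds. Nothing shown explains this step.

Compound 1 and compound 2 differ from compound 3 in more than one place, so a nitrile alone at this carbon remains unresolved. Going by these compounds, a carboxylic acid or an aminomethyl group at this carbon also remains open.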